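The source may report more compounds than this note shows. Statements on the series, on what has been measured and on what is new or still open speak of the compounds shown alone.

Compounds measured so far:

Compound 1, `COc1ccc(-c2nc(CNc3ccc(C(=O)NO)cc3)n(-c3ccccc3)n2)cc1`, in an assay on Sf9 cells for inhibition of protein deacetylase HDAC6 (Homo sapiens), read by fluorescence, with a stated time of 40 min, tested at 100 nM (on this read-out lower numbers stand for less inhibition and higher numbers for more inhibition at the one concentration tested (going by the name of the read-out)), compound 1 gives 77.6%.
Compound 2, `O=C(NO)c1ccc(NCc2nc(-c3ccccc3)nn2-c2cccc(Cl)c2)cc1`, in this assay compound 2 gives 62.3%.

Compound 1 stands highest of the two numbers; the nearest is compound 2, whose number lies lower by a gap that is beyond the usual scatter. For the measured compounds named here, no pair of measured compounds differs in only one place, so no single-step change has yet been measured.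

The account now follows the step from compound 1 to compound 3, `Cc1cccc(-c2nc(CNc3ccc(C(=O)NO)cc3)n(-c3ccccc3)n2)c1`, which is not yet measured in this assay. The difference between the two structures is 3-methylphenyl in place of 4-methoxyphenyl on an aromatic carbon. One aromatic carbon of the shared core carries the group that changes, and the rest of the molecule is kept as in compound 1.

Going by the values given here, with no measured step to guide the size of this change, the expected effect is modest, and a small drop or no change beyond the scatter is the estimate, given as a number 5.6 percentage points lower from compound 1 to compound 3 (within the scatter). For compound 3 in this assay the estimated value is 72%, with a range from 55% to 88%.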

Compound 3, a percentage reported as inhibition, at one concentration (the size of the read-out at that concentration, not a potency): 64.1%
Beside the measured number, compound 3's estimate is 7.9 percentage points above it, within the range that was stated.
By their numbers in this assay, from the lowest: compounds 2 and 3 (each within the scatter of the next); then compound 1.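

In this assay, for the compounds shown here, this is the first single change that can be read, and it shows that the group on this aromatic carbon of the five-membered aromatic ring with 3 nitrogen affects the read-out (a number 13.5 percentage points lower from compound 1 to compound 3 (beyond the scatter)). The step from 4-methoxyphenyl to 3-methylphenyl removes 1 hydrogen-bond acceptor and goes from 8 heavy atoms to 7, but it also alters both the identity of the group on the phenyl ring and where that group sits, so this one step cannot separate those changes. Nothing measured here accounts for the lower number, and the size of the step is all that can be stated.

The compounds shown leave open whether 4-methylphenyl or 3-methoxyphenyl at this same position would stay with compound 1 or with compound 3, which would help separate the choice of group from its placement on the phenyl ring. They also leave open how this position would respond to a phenyl ring carrying an amine or a carboxylic acid.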